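Replacing thiophen-3-yl with prop-1-yn-1-yl

A few compounds are considered here, and "the series" means these few. Any claim that something is new, unique, unknown or untested is made for them only; others in the source may bear on it.

In a functional assay on CCRF-CEM cells (Homo sapiens) (a lower number here means that less compound is tolerated, a higher number that more compound is tolerated), compound 2 (`Cc1cn([C@@H]2O[C@H](CO[Si](C)(C)C(C)(C)C)[C@@]3(OS(=O)(=O)C(c4ccsc4)=C3N)[C@H]2O[Si](C)(C)C(C)(C)C)c(=O)n(C)c1=O`) gives 33000 nM as the higher of two numbers, while compound 1 (`Cc1cn([C@@H]2O[C@H](CO[Si](C)(C)C(C)(C)C)[C@@]3(OS(=O)(=O)C(I)=C3N)[C@H]2O[Si](C)(C)C(C)(C)C)c(=O)n(C)c1=O`) gives 5600 nM as the lower. Compound 3 (`CC#CC1=C(N)[C@@]2(OS1(=O)=O)[C@@H](CO[Si](C)(C)C(C)(C)C)O[C@@H](n1cc(C)c(=O)n(C)c1=O)[C@@H]2O[Si](C)(C)C(C)(C)C`) carries prop-1-yn-1-yl in place of thiophen-3-yl on a double-bonded ring carbon. Among the measured compounds shown here, the only measured step at that carbon, thiophen-3-yl in place of iodo, was modest but beyond the scatter (a 5.9-fold higher number from compound 1 to compound 2 (0.77 log units; beyond the scatter)). Resting on that single step, a modest move toward a lower number is expected in this assay (a 2.2-fold lower number from compound 2 to compound 3 (0.34 log units; beyond the scatter)). The estimate for compound 3 is 15000 nM (range 5000 nM to 45000 nM).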

Compound 3, half-maximal cytotoxic concentration: 5000 nM
Compound 3: the middle estimate sits 3.0-fold (0.48 log units) above what was measured; low and high end bracket the measured number.
By their numbers in this assay, from the lowest: compounds 3 and 1 (each within the scatter of the next); then compound 2.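

In this assay, among the compounds shown here, moving from thiophen-3-yl to prop-1-yn-1-yl gives a 6.6-fold lower number from compound 2 to compound 3 (0.82 log units; beyond the scatter) and so brings the number down, further than the single earlier step suggested. Prop-1-yn-1-yl in place of iodo gives a 1.1-fold lower number from compound 1 to compound 3 (0.05 log units; within the scatter) and these two groups cannot be told apart here, leaving compound 2, with its aromatic ring, alone at the higher number. No measured evidence explains this difference.

From the compounds shown here alone, whether a phenyl ring would also give the higher number remains open. So does the effect of an amine or a carboxylic acid at this carbon.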